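The source may report more compounds than this note shows. Statements on the series, on what has been measured and on what is new or still open speak of the compounds shown alone.

Of the compounds shown here, three that share one core have been measured in an ADME assay on HEK293 cells (Homo sapiens) for cytotoxicity, with a stated time of 72 h; a higher number here means that more compound is needed for the effect, a lower number that less compound is needed. Compound 1 `C=C[C@@](C)(/C=C/c1ccc(OS(=O)(=O)c2ccc(C)cc2)cc1)CCC=C(C)C` gives > 36600 nM, which is a limit of the assay and not a number. Compound 2 `C=C[C@@](C)(/C=C/c1ccc(O)cc1)CCC(O)C(C)(C)O` gives > 36600 nM, again a limit. Compound 3 `C=C[C@@](C)(/C=C/c1ccc(O)c(CO)c1)CCC=C(C)C` gives > 36600 nM, also a limit. For the measured compounds named here, the set therefore offers no measured step, only (the limit of > 36600 nM in this assay, at which 3 of the 3 values shown sit). Compound 4 `C=C[C@@](C)(/C=C/c1ccc(O)c(/C=C/C(N)=O)c1)CCC=C(C)C` carries 2-carbamoylethenyl in place of hydroxymethyl on an aromatic carbon of compound 3 (2-carbamoylethenyl in place of hydroxymethyl on an aromatic carbon). Judging from compound 3 at > 36600 nM, the estimated step that the limit leaves unreadable from compound 3 to compound 4 is expected to stay within the scatter, in neither direction. Compound 4 is expected near 40000 nM, with an estimated range of 18000 nM to 80000 nM.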

Compound 4, half-maximal effective concentration: > 36600 nM
Compound 4 ended at the assay's limit; the forecaster's own chance of this, stated with the estimate: 75%; the middle value is on the limit's open side.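

For the compounds shown here, compound 3 and compound 4 both sit at a limit of the assay and not at a number, so no step between them can be read. The compounds shown leave open what concentration any of them needs for the effect, and whether 2-carbamoylethenyl in place of hydroxymethyl changes it.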